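Adding One Fluoro to Compound 3

This account rests on a few compounds, and the source may have more. Where it says the series, first, only, none or still open, it means among the compounds named here.

Compound 1 `Cc1ccc2c(c1)-c1cnc(n1C)OCCCCCCCCO2`: 34000 nM
Compound 2 `Cn1c2cnc1OCCCCCCCCCCOc1cc3ccccc3cc1-2`: 24000 nM
Compound 3 `C=CCCCCOc1ccccc1-c1cnc(OCCC=C)n1C`: 8000 nM

In a functional assay on MCF7 cells (Homo sapiens) for inhibition, read by colorimetric assay and MTT assay, with a stated time of 72 h (a higher number here means a weaker inhibitor, a lower number a stronger inhibitor), compound 3 gives 8000 nM, the lowest of the three numbers and lower than the other two by more than the usual scatter. Compound 4 `C=CCCCCOc1ccc(F)cc1-c1cnc(OCCC=C)n1C` differs from compound 3 in one place: fluoro in place of hydrogen on an aromatic carbon. This puts fluoro in place of hydrogen on an aromatic carbon, para to a (hex-5-en-1-yl)oxy group. Among the measured compounds shown here, no measured pair shows what this swap does, so no change beyond the scatter is expected in this assay, and the direction is only a slight lean towards stronger inhibition. The expected step is small: a 1.1-fold lower number from compound 3 to compound 4 (0.06 log units; within the scatter). For compound 4 the estimated value is 7000 nM, with an expected range from 3000 nM to 16000 nM.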

Compound 4, half-maximal inhibitory concentration: 43000 nM
Estimate against measurement, compound 4: 6.1-fold (0.79 log units) below, and the stated range ends below it.
By their numbers in this assay, from the lowest: compound 3; then compounds 2, 1 and 4 (each within the scatter of the next).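

In this assay, fluoro in place of hydrogen on this aromatic carbon, para to a (hex-5-en-1-yl)oxy group, gives a 5.4-fold higher number from compound 3 to compound 4 (0.73 log units; beyond the scatter), so inhibition weakens. This position is therefore sensitive to change, even when the change is a single added heavy atom. Nothing measured here explains why.

Whether the loss is specific to fluoro remains open, as a chloro, a methoxy or an amine on the same carbon is not among the compounds shown. As far as these compounds go, whether the swap would act the same way with a shorter chain in place of the (hex-5-en-1-yl)oxy group also remains open.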